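Thienopyrimidine anilines at the A3 receptor: bromo to hydrogen

A few compounds are considered here, and "the series" means these few. Any claim that something is new, unique, unknown or untested is made for them only; others in the source may bear on it.

Measured so far:
compound 1 `COc1ccc(Nc2nc3c(Cl)ncnc3s2)cc1` 5880 nM
compound 2 `Fc1cccc(F)c1Nc1nc2c(Cl)ncnc2s1` 17200 nM
compound 3 `Clc1ncnc2sc(Nc3cccc(Br)c3)nc12` 3900 nM

The three measured compounds share one core and differ only in the aniline ring. In an assay on CHO cells for displacement of a labelled ligand from adenosine receptor A3 (Homo sapiens), read by scintillation counting, with a stated time of 3 h (a higher number here means a weaker inhibitor, a lower number a stronger inhibitor), compound 3 gives 3900 nM, the lowest of the three numbers. Compound 1 sits closest to it, and the gap between the two lies within the usual scatter, so no order between compound 3 and compound 1 can be read from these numbers. Compound 2 is the furthest from compound 3, and that gap lies beyond the scatter, so compound 2 is the weaker of those two in this assay.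

Compound 4 `Clc1ncnc2sc(Nc3ccccc3)nc12` has not yet been measured. It differs from compound 3 by hydrogen in place of bromo on an aromatic carbon, that is, the bromo substituent is removed and the ring position meta to a large group carries a hydrogen. Among the compounds with values here, no measured pair in the set shows this change, so its size is not known from the data.

On what the three values show, removal of the bromo is expected to raise the number somewhat, but a step no larger than the scatter would not be surprising. The step from compound 3 to compound 4 is estimated at a 1.7-fold higher number from compound 3 to compound 4 (0.22 log units; within the scatter). Compound 4 is expected to give about 6500 nM in this assay, within a range from 2500 nM to 17000 nM.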

Compound 4, inhibition constant: 3670 nM
Compound 4: middle estimate off by 1.8-fold (0.25 log units), on the high side, and the stated range covers the measured number.
By their numbers in this assay, from the lowest: compounds 4, 3 and 1 (each within the scatter of the next); then compound 2.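

Read in this assay the exchange of bromo for hydrogen on this aromatic carbon, meta to a large group, gives a 1.1-fold lower number from compound 3 to compound 4 (0.03 log units; within the scatter) and leaves no difference that can be read between the two compounds. Hydrogen in place of methoxy on an aromatic carbon gives a 1.6-fold lower number from compound 1 to compound 4 (0.20 log units; within the scatter) and is likewise a step inside the scatter. The aniline ring with no substituent therefore cannot be told apart from the bromo or methoxy rings in this series, so neither group is shown to be needed for the numbers of these compounds. Nothing at hand accounts for this flat result.

Open, going by these compounds, is whether any group on this aromatic carbon moves the number beyond the scatter at all, for example an amine, a carboxylic acid or a longer chain such as butoxy. Also open, on these data alone, is how much of the binding rests on the chloro of the shared core, which all four compounds carry, and whether an amine in its place would change the number.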